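Removing the chloro from compound 1 in the cytotoxicity series

This account rests on a few compounds, and the source may have more. Where it says the series, first, only, none or still open, it means among the compounds named here.

Compound 1 `S=C(Nc1ccc(Cl)cc1)Nc1nc2ccccc2s1` is the parent of this comparison and is tested in a functional assay on U-937 cells (Homo sapiens) for cytotoxicity, read by MTT assay, with a stated time of 48 h; a lower number here means a stronger inhibitor, a higher number a weaker inhibitor. Compound 1 returns no number there, only the assay limit, > 50000 nM. Compound 1 therefore sits at the limit of > 50000 nM in this assay, at which 1 of the 3 values shown sits, so its position is known only as a limit.

Two measured neighbours frame it. Compound 2 `Fc1ccc2nc(NC(=S)Nc3ccc(Cl)cc3)sc2c1` gives 18700 nM in this assay, and the one-place step from compound 1 to compound 2, fluoro in place of hydrogen on an aromatic carbon, is an at least 2.6-fold lower number from compound 1 to compound 2 (0.42 log units; beyond the scatter). Among the measured compounds shown here, compound 3 `c1ccc2sc(Nc3nc4ccccc4s3)nc2c1` gives 40000 nM in this assay; no one-place step joins it to compound 1 or compound 2, so only its value stands beside theirs.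

Compound 4 `S=C(Nc1ccccc1)Nc1nc2ccccc2s1` differs from compound 1 by hydrogen in place of chloro on an aromatic carbon. For the measured compounds named here, none of the measured steps touches this group: the only measured step, from compound 1 to compound 2, alters the core and leaves the chloro in place. With compound 1 known only as a limit, the step that the limit leaves unreadable from compound 1 to compound 4 is expected to be none beyond the scatter. Compound 4 is accordingly estimated at 60000 nM, within a range from 20000 nM to 200000 nM, most likely again reported as a limit.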

Compound 4, half-maximal inhibitory concentration: > 50000 nM
Compound 4 gave a limit, no number (the forecaster's own chance of this, stated with the estimate: 70%); the middle value lies beyond the limit too.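

In this assay compound 4 gives > 50000 nM as a limit, not a number. Compound 1 also stands at a limit, so no step can be read between compound 1 and compound 4: the limit of > 50000 nM in this assay, at which 2 of the 4 values shown sit.

As far as these compounds go, what the chloro contributes in this assay stays open, with neither compound 1 nor compound 4 giving a number.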